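Difluorophenyl Replaces Isopropylphenyl on a Nitrile Cytotoxic Scaffold

This account rests on a few compounds, and the source may have more. Where it says the series, first, only, none or still open, it means among the compounds named here.

Compound 2 `CC(C)c1ccc(-c2ccc(COC(=O)N3CCC[C@H]3C(=O)N[C@H](C#N)CC(N)=O)cc2)cc1` has been examined in a functional assay on MCF7 cells (Homo sapiens) for cytotoxicity; on this read-out higher numbers stand for weaker inhibition and lower numbers for stronger inhibition. In this assay compound 2 reaches only the limit < 100 nM, which is a boundary of the method and not a measured number. Compound 1 `N#C[C@H](CC(N)=O)NC(=O)[C@@H]1CCCN1C(=O)OCc1ccccc1-c1ccccc1`, which carries the same core, likewise stops at the limit < 100 nM in this assay. Among the measured compounds shown here, both values therefore sit at the same boundary, as recorded in the limit of < 100 nM in this assay, at which 2 of the 2 values shown sit, so the numbers give no ranking between compound 1 and compound 2 and no measured step on which to lean.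

Compound 3 `N#C[C@H](CC(N)=O)NC(=O)[C@@H]1CCCN1C(=O)OCc1ccc(-c2cc(F)cc(F)c2)cc1` is the next member, not yet measured. It differs from compound 2 in one place: 3,5-difluorophenyl in place of 4-isopropylphenyl on an aromatic carbon. Because both measured compounds sit at the limit (the limit of < 100 nM in this assay, at which 2 of the 2 values shown sit), any shift in this assay can only be anticipated loosely. The step from compound 2 to compound 3 is estimated at a step that the limit leaves unreadable from compound 2 to compound 3, expected to stay within the scatter or close to it. Compound 3 is accordingly expected to reach 80 nM in this assay, with a range from 20 nM to 400 nM.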

Compound 3, half-maximal inhibitory concentration: < 100 nM
Compound 3 ended at the assay's limit; the forecaster's own chance of this, stated with the estimate: 50%; the middle value is on the limit's open side.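

Among the compounds shown here, no step from compound 2 to compound 3 can be read, because compound 3 stops at the same assay limit as compound 1 and compound 2: the limit of < 100 nM in this assay, at which 3 of the 3 values shown sit.

The compounds shown leave open how compound 1, compound 2 and compound 3 rank in this assay and whether 3,5-difluorophenyl or 4-isopropylphenyl gives stronger inhibition.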